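This account rests on a few compounds, and the source may have more. Where it says the series, first, only, none or still open, it means among the compounds named here.

Compound 1 `O=C1OC(c2cccc3ccccc23)CN1C1CCN(Cc2cc3ccccc3[nH]2)CC1`: < 50200 nM
Compound 2 `COc1ccc2nccc(C3CN(C4CCN(Cc5cc6ccccc6o5)CC4)C(=O)O3)c2c1`: 1260 nM

Two compounds have so far been run in an in vitro functional assay on RBL cells for antagonist activity at C-C chemokine receptor type 8 (Homo sapiens), read by FLIPR and calcium flux; a higher number here means a weaker inhibitor, a lower number a stronger inhibitor. For compound 1 the result < 50200 nM is a limit of the assay and not a number, as recorded in the limit of < 50200 nM in this assay, at which 1 of the 2 values shown sits. Among the measured compounds shown here, compound 2 gives 1260 nM, the only actual number in this assay so far. Compound 3 `COc1ccc2nccc(C3CN(C4CCN(Cc5ccc(Cl)c(Cl)c5)CC4)C(=O)O3)c2c1` awaits measurement; it differs from compound 2 by 3,4-dichlorophenyl in place of 1-benzofuran-2-yl on a saturated chain carbon bound to an amine nitrogen in a ring. For the measured compounds named here, no step between two measured compounds exists, so nothing calibrates how large this kind of change turns out in this assay. The step from compound 2 to compound 3 is expected to be a 1.4-fold lower number from compound 2 to compound 3 (0.15 log units; within the scatter), small enough to stay within or close to the usual scatter of repeated measurements. Compound 3 is accordingly estimated at 900 nM, in a range from 200 nM to 4000 nM.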

Compound 3, half-maximal inhibitory concentration: 126 nM
Estimate against measurement, compound 3: 7.1-fold (0.85 log units) above; the measured number lies below the stated range.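

In this assay, the group on a saturated chain carbon bound to an amine nitrogen in a ring can move the result well beyond the scatter: 3,4-dichlorophenyl in place of 1-benzofuran-2-yl gives a 10-fold lower number from compound 2 to compound 3 (1.00 log units; beyond the scatter). Among the compounds shown here, this is the first step that can be read between two measured compounds, and it shows that this place matters on the shared core, although the size rests on this one pair. For the compounds shown here, nothing measured so far accounts for the size of this step.

From the compounds shown here alone, whether both chlorines are needed stays open, as does how a phenyl carrying a single chlorine, an unsubstituted phenyl or a trifluoromethyl-bearing phenyl would compare. Also open, going by these compounds, is whether the step would carry over to the core of compound 1, which differs from compound 2 in more than one place.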